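A Methyl Pair Added to the Aryl Group

The source may report more compounds than this note shows. Statements on the series, on what has been measured and on what is new or still open speak of the compounds shown alone.

Compound 1 `COc1ccc(/C=C2\S/C(=N\c3ccccc3)N(C)C2=O)cc1` is tested in a functional assay on HCT-116 cells (Homo sapiens) for antiproliferative activity, read by MTT assay, with a stated time of 72 h; a lower number here means a stronger inhibitor, a higher number a weaker inhibitor. Compound 1 gives only a limit there, > 100000 nM. Compound 3 `COc1ccc(/C=C2\S/C(=N\c3cc(C(F)(F)F)cc(C(F)(F)F)c3)N(C)C2=O)cc1` likewise gives only a limit, > 100000 nM. Compound 2 `COc1ccc(/C=C2/CN(C)/C(=N/c3ccc(F)cc3)S2)cc1`, built on a different core, gives 10000 nM. So compound 1 stands at the limit of > 100000 nM in this assay, at which 2 of the 3 values shown sit, and a number for it is not known. Compound 4 `COc1ccc(/C=C2\S/C(=N\c3c(C)cccc3C)N(C)C2=O)cc1` differs from compound 1 in one place: 2,6-dimethylphenyl in place of phenyl on a double-bonded nitrogen. Among the compounds with values here, no measured pair of compounds shows a change of this kind, so nothing sets the size of the step; the limits of compound 1 and compound 3 point to a core that stays weak. Compound 4 is expected to give 100000 nM, between 30000 nM and 300000 nM, most likely again only a limit. The expected step is a number no higher from compound 1 to compound 4 (the limit leaves the size open), nothing beyond the scatter.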

Compound 4, half-maximal inhibitory concentration: > 100000 nM
Compound 4 was reported as a limit; the forecaster's own chance of this, stated with the estimate: 75%; the middle value sits exactly at the limit.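

In this assay compound 4 gives only a limit, > 100000 nM. Within the data shown here, compound 1 also gives only a limit, so no step between compound 1 and compound 4 can be read. As far as these compounds go, what stays open is how strong either compound really is, and whether 2,6-dimethylphenyl in place of phenyl changes that.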